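Methyl for Hydrogen on the Core Side Chain

The source may report more compounds than this note shows. Statements on the series, on what has been measured and on what is new or still open speak of the compounds shown alone.

The measured compounds, with their results in an in vivo functional assay on the whole organism (Rattus norvegicus) with cysteinyl leukotriene receptor (Homo sapiens) as the target; on this read-out higher numbers stand for an effect only at larger amounts of compound and lower numbers for an effect already at smaller amounts:

- compound 1, `CCCc1c(COc2ccc(C(=O)C(C)Cc3nnn[nH]3)cc2)ccc(C(C)=O)c1O`, gives 9.2 mg/kg
- compound 2, `CCCc1c(COc2ccc(C(=O)C(C)(C)Cc3nnn[nH]3)cc2)ccc(C(C)=O)c1O`, gives 10.8 mg/kg
- compound 3, `CCc1c(COc2ccc(C(=O)CC(C)(C)CC(=O)O)cc2)ccc(C(C)=O)c1O`, gives 1.4 mg/kg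

Compounds 1 and 2 share a core and differ in one place: methyl in place of hydrogen on a saturated chain carbon bound to a carbonyl carbon and two saturated chain carbons. That step, a 1.2-fold higher number from compound 1 to compound 2 (0.07 log units; within the scatter), shows that this kind of change left the result in this assay essentially unchanged.

Compound 3 stands apart. Its number in this assay is the lowest of the three, and the gap to compound 1 and to compound 2 lies beyond the usual scatter, so compound 3 acts at smaller amounts than either. The difference between the core of compound 3 and the core of compound 1 is not broken down here.

Compound 4, `CCCc1c(COc2ccc(C(=O)CC(C)(C)CC(=O)O)cc2)ccc(C(C)=O)c1O`, has not yet been measured. It differs from compound 3 in one place: methyl in place of hydrogen on a saturated chain carbon, two bonds along the chain from an aromatic carbon. Among the measured compounds shown here, this is the same kind of change as the one from compound 1 to compound 2, but at a different place: there the methyl entered on a saturated chain carbon bound to a carbonyl carbon and two saturated chain carbons, here it enters on a saturated chain carbon two bonds along the chain from an aromatic carbon.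

For the measured compounds named here, because the only measured step of this kind, a 1.2-fold higher number from compound 1 to compound 2 (0.07 log units; within the scatter), stayed within the scatter, a small step is expected from compound 3 to compound 4 in this assay, namely a 1.2-fold lower number from compound 3 to compound 4 (0.07 log units; within the scatter). Compound 4 is therefore estimated to give 1.2 mg/kg in this assay, expected to fall between 0.5 mg/kg and 3 mg/kg.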

Compound 4, dose for half-maximal effect: 2.9 mg/kg
The estimate for compound 4 lay 2.4-fold (0.38 log units) below the measured number; the range from low to high includes it.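

Methyl in place of hydrogen on the saturated chain carbon gives a 2.1-fold higher number from compound 3 to compound 4 (0.32 log units; beyond the scatter) in this assay, which is beyond the scatter taken alone, but the comparison with the earlier step on the other core shows no real difference: the same change on two cores in this assay, a 1.2-fold higher number (0.07 log units; within the scatter) from compound 1 to compound 2 and a 2.1-fold higher number (0.32 log units; beyond the scatter) from compound 3 to compound 4, 1.8-fold (0.25 log units) apart, within the scatter of two such steps. So, as far as these two pairs can tell, the change carries over from one core to the other, but the methyl enters at a different place on each core, and two pairs are too few to make a rule for the whole series. The other new steps involve a different change, the 2-(carboxymethyl)-2-methylpropyl group on the carbonyl carbon in place of a tetrazole-bearing group, and give a 3.7-fold lower number from compound 2 to compound 4 (0.57 log units; beyond the scatter) and a 3.2-fold lower number from compound 1 to compound 4 (0.50 log units; beyond the scatter), so they show that this swap moves the result in this assay but add nothing about the methyl step.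

The compounds shown leave open whether the trend continues if the propyl chain is extended to butyl or a longer chain. They also leave open what an amine or a hydroxyl group at the end of that chain would do to the result in this assay.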